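A few compounds are considered here, and "the series" means these few. Any claim that something is new, unique, unknown or untested is made for them only; others in the source may bear on it.

Compound 1 `NC1=NC2(CCOCC2)N(OCCCOc2ccccc2)C(N)=N1` is the unsubstituted parent of the series. In a functional assay on HepG2 cells (Homo sapiens) for antiproliferative activity, read by MTT assay, with a stated time of 72 h (on this read-out lower numbers stand for stronger inhibition and higher numbers for weaker inhibition), compound 1 is recorded as "not determined" (no result reported), so it cannot be placed on the read-out. Among the measured compounds shown here, the one measured member is compound 2 `NC1=NC2(CCSCC2)N(OCCCOc2ccc(Br)cc2)C(N)=N1`; in this assay compound 2 gives 1400 nM, which is the only anchor the series offers. Compound 3 `NC1=NC2(CCOCC2)N(OCCCOc2ccccc2Cl)C(N)=N1` departs from compound 1 by chloro in place of hydrogen on an aromatic carbon. For the measured compounds named here, no step between measured compounds is on record, so the size expected for this change in this assay cannot be read from a pair; the working assumption is a shift no larger than the scatter, with no preferred direction, placing compound 3 near the one measured value because compound 2 gives 1400 nM in this assay. Compound 3 is therefore expected to give about 1500 nM in this assay, estimated to lie between 500 nM and 5000 nM.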

Compound 3, half-maximal inhibitory concentration: 1750 nM
Compound 3: the middle estimate sits 1.2-fold (0.07 log units) below what was measured; low and high end bracket the measured number.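

In this assay, among the compounds shown here, compound 1 stands as "not determined" (no result reported) and compound 3 gives 1750 nM so no step between compound 1 and compound 3 can be read. The compounds shown leave open whether phenyl to 2-chlorophenyl shifts this read-out at all, or in which direction. No evidence on hand bears on this result.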